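A few compounds are considered here, and "the series" means these few. Any claim that something is new, unique, unknown or untested is made for them only; others in the source may bear on it.

Measured so far:

Compound 1 `O=C(NCc1cc(Cl)ccc1-n1cnnn1)[C@@H]1C[C@@H]2C[C@@H]2N1C(=O)[C@H](O)CC1CC1` — in an ADME assay on liver for metabolic stability, with Liver microsome (Homo sapiens) as the target, read by LC-MS, using microsomes (a lower number here means slower removal, a higher number faster removal of the compound), compound 1 gives < 12 mL.min-1.g-1, which is a limit of the assay rather than a number.
Compound 2 `O=C(NCc1cc(Cl)ccc1-n1cnnn1)[C@@H]1C[C@@H]2C[C@@H]2N1C(=O)[C@H](O)C1CCCCC1` — compound 2 gives 150 mL.min-1.g-1.
Compound 3 `CC(C)(C)[C@@H](O)C(=O)N1[C@H](C(=O)NCc2cc(Cl)ccc2-n2cnnn2)C[C@@H]2C[C@@H]21` — compound 3 gives 75 mL.min-1.g-1.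

Among the two numbers recorded, compound 3 has the lowest; its nearest neighbour is compound 2, and the step of a 2.0-fold lower number from compound 2 to compound 3 (0.30 log units; within the scatter) stays within the scatter, so the two cannot be ordered. Compound 1 contributes only the limit (the limit of < 12 mL.min-1.g-1 in this assay, at which 1 of the 3 values shown sits).

Compound 4 `O=C(NCc1cc(Cl)ccc1-n1cnnn1)[C@@H]1C[C@@H]2C[C@@H]2N1C(=O)[C@H](O)c1ccccc1F` is not yet measured. It differs from compound 3 as follows:

2-fluorophenyl in place of tert-butyl on a saturated chain carbon bound to a carbonyl carbon and an oxygen on a saturated carbon

Going by the values given here, two measured steps touch the same place. The step of an at least 12-fold higher number from compound 1 to compound 2 (1.09 log units; beyond the scatter) and the step of an at least 6.2-fold higher number from compound 1 to compound 3 (0.79 log units; beyond the scatter) both show that replacing cyclopropylmethyl at this carbon raised clearance, while the step of a 2.0-fold lower number from compound 2 to compound 3 (0.30 log units; within the scatter) shows that exchanging one of the larger groups for the other moved nothing beyond the scatter. Among the compounds with values here, no measured step involves an aromatic ring at this position, so the data give no direct guide for 2-fluorophenyl. The expectation is therefore a step of a 1.2-fold higher number from compound 3 to compound 4 (0.08 log units; within the scatter) that stays within the scatter. Compound 4 is estimated at 90 mL.min-1.g-1, with a range from 35 mL.min-1.g-1 to 250 mL.min-1.g-1.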

Compound 4, intrinsic clearance in microsomes: < 12 mL.min-1.g-1
Compound 4: only a limit was reported (the forecaster's own chance of this, stated with the estimate: 5%); middle value at least 7.5-fold (0.87 log units) away from the limit.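

Going by these compounds alone, at the saturated chain carbon bound to a carbonyl carbon and an oxygen on a saturated carbon, this assay now gives a first reading for an aromatic ring, with an at least 6.2-fold lower number from compound 3 to compound 4 (0.79 log units; beyond the scatter) and an at least 12-fold lower number from compound 2 to compound 4 (1.09 log units; beyond the scatter). The earlier compounds shown here left open whether replacing cyclopropylmethyl with any larger group would bring faster removal, but compound 4 goes against that pattern: its 2-fluorophenyl has 7 heavy atoms against 4 for tert-butyl, so the heavy atom count alone does not order the compounds at this position. The result for compound 4 is a limit and not a number, as is the result for compound 1, so the step between these two cannot be read and they cannot be ordered: the limit of < 12 mL.min-1.g-1 in this assay, at which 2 of the 4 values shown sit.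

The compounds shown do not separate the part played by the aromatic ring from that of its fluorine, and a plain phenyl or a pyridine ring at this carbon would be needed to tell the two apart. On these data alone, how far the true clearance of compound 1 and compound 4 lies from the limit also remains open.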